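Chloro to dimethylamino on the saturated chain carbon

A few compounds are considered here, and "the series" means these few. Any claim that something is new, unique, unknown or untested is made for them only; others in the source may bear on it.

Two compounds carry numbers. Compound 1 `COc1ccc(-c2cc(=O)c3cc(CN(C)C)ccc3o2)cc1` in a functional assay on the whole organism (strain Wistar albino) for inhibition, with Rattus norvegicus as the target, read by paw edema, with stated times of 30 min and 3 h, at a dose of 20 mg/kg by the oral route (a higher number here means more inhibition at the dose given (going by the name of the read-out), a lower number less inhibition), gives 53.1%. Compound 2 `COc1ccc(-c2cc(=O)c3cc(CCl)ccc3o2)cc1OC` in this assay gives 49.4%, the lowest of the two numbers, yet compound 1 sits within the scatter of it, so the two are not separated. Compound 3 `COc1ccc(-c2cc(=O)c3cc(CN(C)C)ccc3o2)cc1OC` awaits measurement. It differs from compound 2 by dimethylamino in place of chloro on a saturated chain carbon bound to an aromatic carbon. Within the data shown here, no measured pair isolates this change. The step of a number 2.6 percentage points higher from compound 2 to compound 3 (within the scatter) is expected to stay within the scatter because compound 1 gives 53.1%. Compound 3 is estimated at 52%, ranging from 40% to 64%.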

Compound 3, a percentage reported as inhibition, in the whole organism at one dose (the size of the read-out at that dose, not a potency): 51%
Compound 3: middle estimate off by 1 percentage points, on the high side, and the stated range covers the measured number.
By their numbers in this assay, from the lowest: compounds 2, 3 and 1 (each within the scatter of the next).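

In this assay, the exchange of chloro for dimethylamino on a saturated chain carbon bound to an aromatic carbon now has a measured pair, with a number 1.6 percentage points higher from compound 2 to compound 3 (within the scatter) as its step, so the two groups are not separated at this position. Methoxy in place of hydrogen on an aromatic carbon also has a measured pair, with a number 2.1 percentage points lower from compound 1 to compound 3 (within the scatter) as its step, and it does not separate those compounds either. No measured data bear on the reason for either step.

Still open is whether a carboxylic acid or a morpholine on the same chain carbon would stay within the scatter of these compounds. As far as these compounds go, a longer chain carrying dimethylamino is equally open.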